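Ketone replaced by alkene on a shared core

This account rests on a few compounds, and the source may have more. Where it says the series, first, only, none or still open, it means among the compounds named here.

Three compounds share one core and differ only in what sits on one aromatic carbon. Compound 1 `CCc1nn(CCCN2CCN(c3ccc(C)cc3)CC2)c(=O)c(N)c1C(C)=O` carries an acetyl group and in a functional assay on the whole organism (Abdomen, strain Swiss) for inhibition, with Mus musculus as the target, with stated times of 30 min, 10 min and 5 min, at a dose of 20 mg/kg by the oral route (a lower number here means a weaker effect, a higher number a stronger effect of the compound at the dose given), gives 42%. Compound 2 `CCCC(=O)c1c(C)nn(CCCN2CCN(c3ccc(C)cc3)CC2)c(=O)c1N` carries a propylcarbonyl group and in this assay gives 25%. Compound 3 `C=Cc1c(CC)nn(CCCN2CCN(c3ccc(C)cc3)CC2)c(=O)c1N` carries a vinyl group and in this assay gives 0%. Of these three numbers, compound 2 stands second highest: compound 1 lies above it beyond the scatter, and compound 3 lies below it, also beyond the scatter.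

Compound 4 `CCC/C=C/c1c(C)nn(CCCN2CCN(c3ccc(C)cc3)CC2)c(=O)c1N` has not yet been measured. Its change from compound 2 is pent-1-en-1-yl in place of propylcarbonyl on an aromatic carbon. For the measured compounds named here, one measured step bears on this exchange: a number 42 percentage points lower from compound 1 to compound 3 (beyond the scatter). That step, of the same kind as the one now considered, was large and downward, and compound 3 reached the bottom of the read-out. The analyst therefore expects a downward step in this assay for compound 4 as well, limited only by the floor of the read-out. The estimated value for compound 4 is 5%, with an expected range from 0% to 20%. This corresponds to an expected step of a number 20 percentage points lower from compound 2 to compound 4 (beyond the scatter).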

Compound 4, a percentage reported as inhibition, in the whole organism at one dose (the size of the read-out at that dose, not a potency): 16%
Compound 4: middle estimate off by 11 percentage points, on the low side; the range from low to high includes it.
By their numbers in this assay, from the lowest: compound 3; then compounds 4 and 2 (each within the scatter of the next); then compound 1.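

In this assay, putting pent-1-en-1-yl in place of propylcarbonyl on this aromatic carbon, opposite the ring nitrogen, gives a number 9 percentage points lower from compound 2 to compound 4 (within the scatter), so in this pair the loss of the carbonyl and its hydrogen-bond acceptor, with the heavy-atom count unchanged, leaves a difference that cannot be told from the scatter. For the compounds shown here, the only earlier exchange of a ketone for an alkene, a number 42 percentage points lower from compound 1 to compound 3 (beyond the scatter), lies beyond the scatter, so the two pairs show that replacing a ketone with an alkene at this position does not bring one fixed outcome in this whole-organism read-out. No measurement at hand explains why the two pairs part ways.

Compounds 1 and 2 differ in more than one place, as do compounds 3 and 4, so the shown set cannot separate the length of the group on this carbon from the ethyl or methyl group on the ring. On these data alone, how a saturated pentyl chain, a primary amine or a carboxylic acid on this carbon would read in this assay remains open.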